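The source may hold more compounds than are shown below. What is called first, only, known or untested is meant among the compounds shown, and "the series" means these compounds.

Compound 1 `CSc1ccc(Cc2nn(C(C)(C)C)c(=O)c3ccccc23)cc1` — in a functional assay on aorta with Alpha-1D adrenergic receptor (Rattus norvegicus) as the target (on this read-out lower numbers stand for an effect already at smaller amounts and higher numbers for an effect only at larger amounts of compound), compound 1 gives > 100000 nM, which is a limit of the assay and not a number.
Compound 2 `COc1ccc(Cc2nn(-c3ccccc3)c(=O)c3ccccc23)cc1OC` — in this assay compound 2 gives > 100000 nM, again a limit rather than a number.
Compound 3 `CC(C)(C)n1nc(Cc2ccc(Cl)cc2)c2ccccc2c1=O` — in this assay compound 3 gives > 100000 nM, also a limit.

Compound 3 therefore stands at the edge of what this assay can report, and it does not stand alone there: the limit of > 100000 nM in this assay, at which 3 of the 3 values shown sit. Among the measured compounds shown here, the single step between measured compounds that differ in one place, a step that the two limits leave unreadable from compound 1 to compound 3, has a size that the two limits hide, so it gives no readable direction.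

Compound 4 `O=c1c2ccccc2c(Cc2ccc(Cl)cc2)nn1-c1ccc(Br)cc1` differs from compound 3 in one place: 4-bromophenyl in place of tert-butyl on an aromatic nitrogen. For the measured compounds named here, no measured step bears on this exchange on the aromatic nitrogen. The nearest point of comparison is compound 2, which also carries a phenyl group on an aromatic nitrogen of the shared core and sits at the limit in this assay. With every shown value at the limit, the step that the limit leaves unreadable from compound 3 to compound 4 is expected to be none beyond the scatter, most likely ending again at a limit. For compound 4 in this assay the estimate is 150000 nM, within a range from 30000 nM to 1000000 nM.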

Compound 4, half-maximal effective concentration: > 30000 nM
Compound 4 gave a limit, no number (the forecaster's own chance of this, stated with the estimate: 85%); the middle value lies beyond the limit too.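

In this assay compound 4 gives > 30000 nM, a limit and not a number. Compound 3 gives > 100000 nM, also a limit, so no step can be read between compound 3 and compound 4. The compounds shown leave open whether any member of this series reaches a measurable value in this assay.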